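The compounds below may be only part of what the source reports. "The series", "measured", "known", "first", "only" and "open" are said of these compounds alone.

Compound 1 `Cc1ccccc1-c1nn(Cc2ccc(F)cc2)cc1CNCCN1CCN(C)CC1`: in an ADME assay on Huh-7 cells (Homo sapiens) for cytotoxicity (on this read-out higher numbers stand for lower toxicity in this test and lower numbers for higher toxicity in this test), compound 1 gives > 20000 nM, a limit of the assay.
Compound 2 `CN1CCN(CCNCc2cn(-c3ccc([N+](=O)[O-])cc3)nc2-c2ccc(OC(F)(F)F)cc2)CC1`: in this assay compound 2 gives 4400 nM.
Compound 3 `COc1ccc(-n2cc(CNCCN3CCN(C)CC3)c(-c3ccccc3C)n2)cc1`: in this assay compound 3 gives > 20000 nM, again a limit of the assay.

Compound 3 therefore stands at the limit of > 20000 nM in this assay, at which 2 of the 3 values shown sit, and only compound 2 has a number. Compound 4 `Cc1ccccc1-c1nn(-c2ccc(F)c(F)c2)cc1CNCCN1CCN(C)CC1` differs from compound 3 by 3,4-difluorophenyl in place of 4-methoxyphenyl on an aromatic nitrogen. Among the compounds with values here, the one measured step at this position, a step that the two limits leave unreadable from compound 1 to compound 3, runs between two limits and gives no readable size. Compound 2 differs from compound 3 in more than one place, so its number says little about this step. With no readable step to lean on, the expectation for compound 4 is a value near the limit again, so compound 4 is estimated at 15000 nM (range 4000 nM to 40000 nM), an expected step of an at least 1.3-fold lower number from compound 3 to compound 4 (0.12 log units; that floor lies within the scatter) in this assay.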

Compound 4, half-maximal cytotoxic concentration: > 20000 nM
Compound 4 was reported as a limit (the forecaster's own chance of this, stated with the estimate: 50%); at least 1.3-fold (0.12 log units) between middle value and limit.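

No step can be read among compound 1, compound 3 and compound 4, whose results in this assay are all limits rather than numbers: the limit of > 20000 nM in this assay, at which 3 of the 4 values shown sit.

Whether the different groups on the aromatic nitrogen of these compounds change the cytotoxic concentration at all remains open.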